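Pyridin-4-yl in place of trifluoromethyl on compound 1

This account rests on a few compounds, and the source may have more. Where it says the series, first, only, none or still open, it means among the compounds named here.

Among the measured compounds shown here, in a functional assay on KG-1 cells (Homo sapiens) for cytotoxicity, read by luminescence and CellTiter-Glo, with a stated time of 3 days (a higher number here means a weaker inhibitor, a lower number a stronger inhibitor), three compounds have numbers so far. Compound 1 (`N#Cc1ccc(NC(=O)c2ccc(C(F)(F)F)cc2O)cc1`) gives 1440 nM, the middle of the three values. Compound 2 (`N#Cc1ccc(NC(=O)c2ccc3cccnc3c2O)c(C#N)c1`) stands higher at 3770 nM, and compound 3 (`O=C(Nc1ccc(Cl)c(C(F)(F)F)c1)c1cc(F)ccc1O`) stands lower at 540 nM. Both gaps from compound 1 lie beyond the usual scatter. No pair among these three differs in one place only, so no measured step is available to calibrate the next change.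

Compound 4 (`N#Cc1ccc(NC(=O)c2ccc(-c3ccncc3)cc2O)cc1`) keeps the core of compound 1 and carries pyridin-4-yl in place of trifluoromethyl on an aromatic carbon, meta to a hydroxy group and para to a large group: pyridin-4-yl in place of trifluoromethyl on an aromatic carbon. For the measured compounds named here, the measured compounds offer no precedent for this exchange, so the expectation is loose: a small weakening in this assay, possibly not beyond the scatter. The estimated step is a 1.4-fold higher number from compound 1 to compound 4 (0.14 log units; within the scatter). Compound 4 is expected at 2000 nM, with an estimated range of 500 nM to 8000 nM.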

Compound 4, half-maximal inhibitory concentration: 8840 nM
The estimate for compound 4 lay 4.4-fold (0.65 log units) below the measured number, and the stated range ends below it.
By their numbers in this assay, from the lowest: compound 3; then compound 1; then compound 2; then compound 4.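

At the aromatic carbon meta to a hydroxy group and para to a large group, the substituent matters: in this assay, pyridin-4-yl in place of trifluoromethyl brings a 6.1-fold higher number from compound 1 to compound 4 (0.79 log units; beyond the scatter). Among the compounds shown here, this is the first single-place step, and it shows that, on the core of compound 1, this six-membered aromatic ring is tolerated less well than trifluoromethyl in this cell read-out. No measurement on hand bears on the reason for this loss.

Still open, as far as these compounds go, is whether the step follows from the ring as a whole or from its ring nitrogen, a question that phenyl on the same carbon would address. Also open, from the compounds shown here alone, is how a smaller group such as methyl or chlorine, or a charged one such as an amine or a carboxylic acid, would read here.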